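Compound 4: a non-aromatic group on the shared core

This account rests on a few compounds, and the source may have more. Where it says the series, first, only, none or still open, it means among the compounds named here.

In a functional assay on MDA-MB-231 cells (Homo sapiens) for antiproliferative activity, read by MTT assay, with a stated time of 48 h (a lower number here means a stronger inhibitor, a higher number a weaker inhibitor), compound 1 (`C=CS(=O)(=O)N1CCN(c2ncnc3sc(-c4ccc(C#N)cc4)cc23)CC1`) gives 8050 nM. Compound 2 (`C=CS(=O)(=O)N1CCN(c2ncnc3sc(-c4cn(C)nc4C(F)(F)F)cc23)CC1`) gives 10400 nM. The step between these two is a 1.3-fold higher number from compound 1 to compound 2 (0.11 log units; within the scatter). Compound 3 (`C=CS(=O)(=O)N1CCN(c2ncnc3sc(-c4c(C)noc4C)cc23)CC1`) gives 28200 nM, the highest number of the three and the weakest result so far.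

Compound 4 (`C=CS(=O)(=O)N1CCN(c2ncnc3sc(C4=CCCCC4)cc23)CC1`) differs from compound 3 as follows: cyclohex-1-en-1-yl in place of 3,5-dimethyl-1,2-oxazol-4-yl on an aromatic carbon. This places cyclohex-1-en-1-yl in place of 3,5-dimethyl-1,2-oxazol-4-yl on an aromatic carbon.

Within the data shown here, no measured compound carries a non-aromatic group here, so the evidence is indirect. The two steps that bear on this change are a 3.5-fold higher number from compound 1 to compound 3 (0.54 log units; beyond the scatter) and a 2.7-fold higher number from compound 2 to compound 3 (0.43 log units; beyond the scatter). Both are modest and show that replacing the 3,5-dimethyl-1,2-oxazol-4-yl group has so far given lower numbers. In this assay, a small shift towards a lower number is therefore expected, probably not beyond the scatter. The expected step is a 1.9-fold lower number from compound 3 to compound 4 (0.27 log units; within the scatter). Compound 4 is estimated at 15000 nM, with an expected range of 6000 nM to 38000 nM.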

Compound 4, half-maximal inhibitory concentration: > 50000 nM
Compound 4 was reported as a limit (the forecaster's own chance of this, stated with the estimate: 10%); middle value at least 3.3-fold (0.52 log units) away from the limit.
By their numbers in this assay, from the lowest: compounds 1 and 2 (each within the scatter of the next); then compound 3. At a limit, above all of these: compound 4.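

Compound 4 is reported in this assay only as a limit, not as a number: the limit of > 50000 nM in this assay, at which 1 of the 4 values shown sits. With cyclohex-1-en-1-yl on this aromatic carbon next to the ring sulfur, the series shows an at least 6.2-fold higher number from compound 1 to compound 4 (0.79 log units; beyond the scatter) and an at least 4.8-fold higher number from compound 2 to compound 4 (0.68 log units; beyond the scatter), so a ring of carbon only that is non-aromatic does not retain the activity of the two aromatic groups in compounds 1 and 2. The remaining step is an at least 1.7-fold higher number from compound 3 to compound 4 (0.24 log units; that floor lies within the scatter), so the lower numbers seen so far on leaving 3,5-dimethyl-1,2-oxazol-4-yl do not extend to this group, although that floor does not separate compound 4 from compound 3.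

With one non-aromatic group shown, it remains open whether the ring's non-aromatic character or its lack of hetero atoms matters more. A piperidin-4-yl ring carrying its amine, or a plain phenyl ring without the nitrile, would help separate these readings.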